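A few compounds are considered here, and "the series" means these few. Any claim that something is new, unique, unknown or untested is made for them only; others in the source may bear on it.

Measured so far in a functional assay on SK-MEL-2 cells (Homo sapiens) for inhibition, read by sulforhodamine B assay, with a stated time of 48 h, tested at 10 uM; on this read-out higher numbers stand for more inhibition at the one concentration tested (going by the name of the read-out) and lower numbers for less inhibition: compound 1 `O=Cc1ccc(-c2cn3ccnc3c(-c3ccc4ncn(C5CCCCC5)c4c3)n2)cc1` gives 27.8%; compound 2 `c1ccc2c(-c3cn4ccnc4c(-c4ccc5ncn(C6CCCCC6)c5c4)n3)cccc2c1` gives 2.3%; compound 3 `Clc1ccc(-c2cn3ccnc3c(-c3ccc4ncn(C5CCCCC5)c4c3)n2)cc1` gives 10.9%.

Compound 3 stands second highest of the three numbers; its gap to compound 2 is within the scatter, whereas the step of a number 16.9 percentage points lower from compound 1 to compound 3 (beyond the scatter) lies beyond it. Compound 4 `COc1ccccc1-c1cn2ccnc2c(-c2ccc3ncn(C4CCCCC4)c3c2)n1` differs from compound 3 by 2-methoxyphenyl in place of 4-chlorophenyl on an aromatic carbon. Among the compounds with values here, two measured steps bear on changes at this same position: a number 16.9 percentage points lower from compound 1 to compound 3 (beyond the scatter), a modest drop, and a number 8.6 percentage points higher from compound 2 to compound 3 (within the scatter), within the scatter. Within the data shown here, no compound carrying a methoxy group has been measured, so the direction of this change is not anchored. The step of a number 2.1 percentage points higher from compound 3 to compound 4 (within the scatter) is expected to stay within the scatter, with the low range of compounds 2 and 3 as the reference. Compound 4 is estimated at 13%, range 0% to 30%.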

Compound 4, a percentage reported as inhibition, at one concentration (the size of the read-out at that concentration, not a potency): 12.1%
Beside the measured number, compound 4's estimate is 0.9 percentage points above it; low and high end bracket the measured number.
By their numbers in this assay, from the lowest: compounds 2, 3 and 4 (each within the scatter of the next); then compound 1.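

In this assay the 2-methoxyphenyl group joins the low cluster at this position: a number 1.2 percentage points higher from compound 3 to compound 4 (within the scatter) and a number 9.8 percentage points higher from compound 2 to compound 4 (within the scatter) both stay small, while a number 15.7 percentage points lower from compound 1 to compound 4 (beyond the scatter) again leaves the 4-formylphenyl compound apart. Three different groups now give numbers within the scatter of the next, and compound 1 alone stands clear of them. The oxygen of 2-methoxyphenyl does not bring compound 4 up to compound 1, and no supporting data explain this. Open, on these data alone, is whether the number of compound 1 depends on the formyl group itself, and how an amine or a carboxylic acid on the phenyl ring would read.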